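Chloromethylbenzyl purines: chloro to amino on the core

The compounds below may be only part of what the source reports. "The series", "measured", "known", "first", "only" and "open" are said of these compounds alone.

compound 1 `ClCc1ccccc1Cn1cnc2c(Cl)nc(Cl)nc21` — a functional assay on OVCAR-4 cells (Homo sapiens) for cytotoxicity, read by sulforhodamine B assay, with a stated time of 48 h; on this read-out higher numbers stand for lower toxicity in this test and lower numbers for higher toxicity in this test: "not determined" (no result reported)
compound 2 `ClCc1cccc(Cn2cnc3ncnc(Cl)c32)c1` — this assay: 46800 nM
compound 3 `ClCc1ccc(Cn2cnc3nc(Cl)nc(Cl)c32)cc1` — this assay: "not determined" (no result reported)

Compound 1 stands without a number in this assay; compound 3 is likewise without a result, and compound 2 alone gives a value. Compound 4 `Nc1nc(Cl)c2ncn(Cc3ccccc3CCl)c2n1` differs from compound 1 by amino in place of chloro on an aromatic carbon. Among the compounds with values here, no pair of measured compounds carries this change, so its size and direction in this assay cannot be read from the series; no shift beyond the scatter is assumed. Within the data shown here, the only anchor is compound 2 with 46800 nM in this assay. Compound 4 is expected near that level, at 40000 nM, with a range from 10000 nM to 150000 nM, and a fair chance that only a limit is reported.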

Compound 4, concentration lethal to 50% of the cells: 50100 nM
Estimate against measurement, compound 4: 1.3-fold (0.10 log units) below; measured number inside the range.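

No step can be read for compound 4: compound 1 carries "not determined" (no result reported) and offers no number to compare. The compounds shown leave open what amino in place of chloro does on the shared core. No measured evidence bears on this result.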